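From Ethyl to Cyano on a Shared Core

This account rests on a few compounds, and the source may have more. Where it says the series, first, only, none or still open, it means among the compounds named here.

In a functional assay on A549 cells (Homo sapiens) for inhibition, read by MTT assay, with a stated time of 48 h (on this read-out lower numbers stand for stronger inhibition and higher numbers for weaker inhibition), compound 1 (`CCc1ccc(-c2nc3ccccn3c2Sc2ccccc2)cc1`) gives 56200 nM. For the measured compounds named here, compound 2 (`c1ccc(Sc2c(-c3ccccc3)nc3ccc(-c4ccccc4)cn23)cc1`) gives 54200 nM, so the two values lie within the usual scatter of each other and compound 1 stands level with the only other measured compound. Compound 3 (`N#Cc1ccc(-c2nc3ccccn3c2Sc2ccccc2)cc1`) departs from compound 1 in one place: cyano in place of ethyl on an aromatic carbon. Cyano takes the place of ethyl on an aromatic carbon, para to a large group, turning 4-ethylphenyl into 4-cyanophenyl. Going by the values given here, no two measured compounds differ in just one place, so the data give no direct size for such a change. With only these two values as anchors, no shift beyond the scatter is expected in this assay, though the uncertainty is wide. The expected change is a 1.2-fold lower number from compound 1 to compound 3 (0.10 log units; within the scatter). For compound 3 the estimated value is 45000 nM, with an expected range from 15000 nM to 100000 nM.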

Compound 3, half-maximal inhibitory concentration: 35200 nM
The estimate for compound 3 lay 1.3-fold (0.11 log units) above the measured number, and the stated range covers the measured number.
By their numbers in this assay, from the lowest: compounds 3, 2 and 1 (each within the scatter of the next).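

In this assay, this pair gives the first direct size for a change at this position on the shared core: a 1.6-fold lower number from compound 1 to compound 3 (0.20 log units; within the scatter). Replacing ethyl with cyano on this aromatic carbon keeps the count of heavy atoms and adds a triple bond and a hydrogen-bond acceptor, yet the step cannot be told apart from repeat measurements, so no effect of this change on the read-out is shown. No measurement at hand bears on this result.

One step cannot show whether this position responds at all, or whether an amine, a carboxylic acid or a longer chain in place of ethyl would move the number beyond the scatter. It also leaves open whether the same exchange would read alike with a phenyl group added elsewhere on the shared core, as in compound 2.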